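From phenylsulfonyl to (4-methylphenyl)sulfonyl in compound 4

This account rests on a few compounds, and the source may have more. Where it says the series, first, only, none or still open, it means among the compounds named here.

In a functional assay on HepG2 cells (Homo sapiens) for cytotoxicity, read by MTT assay, with a stated time of 24 h (a lower number here means a stronger inhibitor, a higher number a weaker inhibitor), compound 1 (`CN1C/C(=C\c2cccnc2)C(=O)/C(=C/c2ccccc2F)C1`) gives 4810 nM, compound 2 (`O=C1/C(=C/c2cccnc2)CNC/C1=C\c1ccccc1F`) gives 21000 nM and compound 3 (`O=C1/C(=C/c2cccnc2)CN(S(=O)(=O)c2ccccc2)C/C1=C\c1ccccc1F`) gives 8210 nM. Compound 3 therefore lies within the scatter of compound 1, with a 1.7-fold higher number from compound 1 to compound 3 (0.23 log units; within the scatter), and has a lower number than compound 2, with a 2.6-fold lower number from compound 2 to compound 3 (0.41 log units; beyond the scatter). Compound 4 (`Cc1ccc(S(=O)(=O)N2C/C(=C\c3cccnc3)C(=O)/C(=C/c3ccccc3F)C2)cc1`) carries methyl in place of hydrogen on an aromatic carbon, para to a large group: methyl in place of hydrogen on an aromatic carbon. Among the measured compounds shown here, no measured step touches that aromatic ring. The closest evidence is the changes on the amine nitrogen, the largest being a 4.4-fold higher number from compound 1 to compound 2 (0.64 log units; beyond the scatter), so no step beyond the scatter is expected. The expected step is a 1.1-fold lower number from compound 3 to compound 4 (0.04 log units; within the scatter). Compound 4 is estimated at 7500 nM, with an expected range from 3800 nM to 15000 nM.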

Compound 4, half-maximal inhibitory concentration: 4200 nM
Compound 4: middle estimate off by 1.8-fold (0.25 log units), on the high side; the measured number falls inside the stated range.
By their numbers in this assay, from the lowest: compounds 4, 1 and 3 (each within the scatter of the next); then compound 2.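

In this assay, among the compounds shown here, methyl in place of hydrogen on this aromatic carbon, para to a large group, is the only measured change on that ring, and it stays within the scatter (a 2.0-fold lower number from compound 3 to compound 4 (0.29 log units; within the scatter)). On the amine nitrogen, (4-methylphenyl)sulfonyl is within the scatter of methyl (a 1.1-fold lower number from compound 1 to compound 4 (0.06 log units; within the scatter)) but beyond the scatter of hydrogen (a 5.0-fold lower number from compound 2 to compound 4 (0.70 log units; beyond the scatter)). Nothing measured here explains these numbers. The compounds shown leave open whether methoxy, chlorine or a longer chain such as ethyl at this ring carbon would give a step beyond the scatter. From the compounds shown here alone, how an acetyl group on the amine nitrogen would compare also remains open.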